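The compounds below may be only part of what the source reports. "The series", "measured", "known", "first", "only" and "open" are said of these compounds alone.

Three compounds have been measured in a functional assay on A-375 cells (Homo sapiens) for activation, with a stated time of 3 days; a lower number here means that less compound is needed, a higher number that more compound is needed for the effect:

- Compound 1 `O=C(Nc1ccc(-c2cscn2)cc1)C1CCCN(Cc2ccccc2F)C1`: 7000 nM
- Compound 2 `O=C(Nc1ccc(-c2cscn2)cc1)C1CCCN(Cc2ccc(Cl)c(Cl)c2)C1`: 3000 nM
- Compound 3 `O=C(Nc1ccc(-c2cscn2)cc1)C1CCCN(Cc2cccnc2)C1`: > 20000 nM (a limit of the assay, not a number)

Compound 3 therefore has no exact position on the scale, and the record shows (the limit of > 20000 nM in this assay, at which 1 of the 3 values shown sits). Compound 4 `O=C(Nc1ccc(-c2cscn2)cc1)C1CCCN(Cc2ccc3cn[nH]c3c2)C1` carries 1H-indazol-6-yl in place of pyridin-3-yl on a saturated chain carbon bound to an amine nitrogen in a ring.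

Two measured steps changed the group at this same place and brought in pyridin-3-yl: an at least 2.8-fold higher number from compound 1 to compound 3 (0.45 log units; beyond the scatter) and an at least 6.6-fold higher number from compound 2 to compound 3 (0.82 log units; beyond the scatter). Both are limits on size, and both point away from pyridin-3-yl as the better group. A third step, a 2.3-fold lower number from compound 1 to compound 2 (0.37 log units; beyond the scatter), shows that the two compounds without pyridin-3-yl also differ from each other. Neither of them contains 1H-indazol-6-yl, so they serve only as a guide. A modest change toward a lower number is expected, an at least 3.3-fold lower number from compound 3 to compound 4 (0.52 log units; beyond the scatter). For compound 4 the estimate is 6000 nM, with an expected range from 1800 nM to 20000 nM.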

Compound 4, half-maximal effective concentration: > 20000 nM
Compound 4 ended at the assay's limit; the forecaster's own chance of this, stated with the estimate: 20%; at least 3.3-fold (0.52 log units) between middle value and limit.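

In this assay compound 4 gives > 20000 nM, a limit of the assay and not a number. A second group with ring nitrogen, now also carrying a hydrogen-bond donor, thus ends where pyridin-3-yl did: the limit of > 20000 nM in this assay, at which 2 of the 4 values shown sit. Against the two halogen-carrying phenyl groups the change gives an at least 6.6-fold higher number from compound 2 to compound 4 (0.82 log units; beyond the scatter) and an at least 2.8-fold higher number from compound 1 to compound 4 (0.45 log units; beyond the scatter), so among the four compounds shown, only the groups without ring nitrogen reach a measured number at this position.

On these data alone, the step from compound 3 to compound 4 cannot be read, so any order between 1H-indazol-6-yl and pyridin-3-yl stays open. Also open, as far as these compounds go, is whether unsubstituted phenyl, or a phenyl carrying a methoxy group, would give a measured number on a saturated chain carbon bound to an amine nitrogen in a ring.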